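This account rests on a few compounds, and the source may have more. Where it says the series, first, only, none or still open, it means among the compounds named here.

Compound 1, `COc1ccc(CNc2ncc(C(=O)O)c3nc(-c4ccco4)nn23)cc1OC`: > 30000 nM
Compound 2, `CNC(=O)c1cnc(NC(=O)NC2CCCCC2)n2nc(-c3ccco3)nc12`: > 30000 nM

In a functional assay on CHO cells for antagonist activity at adenosine receptor A2b (Homo sapiens) (a lower number here means a stronger inhibitor, a higher number a weaker inhibitor), compound 2 gives > 30000 nM, which is a limit of the assay and not a number. Compound 1 likewise gives > 30000 nM, again a limit. Both values shown thus sit at the limit of > 30000 nM in this assay, at which 2 of the 2 values shown sit, so compound 2 has no measured potency to build on. Compound 3, `O=C(Nc1ncc(C(=O)O)c2nc(-c3ccco3)nn12)NC1CCCCC1`, differs from compound 2 by hydroxy in place of methylamino on a carbonyl carbon. Among the compounds with values here, no step between measured compounds covers this change; compound 1, which also carries a carboxy group, stands at a limit as well. Compound 3 is expected to stay at the limit, with no shift beyond the scatter, a step that the limit leaves unreadable from compound 2 to compound 3. The estimate for compound 3 is 50000 nM, ranging from 10000 nM to 200000 nM.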

Compound 3, inhibition constant: > 30000 nM
Compound 3 was reported as a limit; the forecaster's own chance of this, stated with the estimate: 85%; the middle value does not contradict the limit.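

No step can be read between compound 2 and compound 3, as both stand at a limit: the limit of > 30000 nM in this assay, at which 3 of the 3 values shown sit.

The compounds shown leave open whether methylcarbamoyl or carboxy makes any difference to potency in this assay, and which compound on the shared core would give a measurable value.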